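This account rests on a few compounds, and the source may have more. Where it says the series, first, only, none or still open, it means among the compounds named here.

Measured compounds:
compound 1 `CCC[C@@H](OC(C)=O)C1=C(Br)/C(=C/Br)OC1=O`: 1.7 ug/mL
compound 2 `CCC[C@@H](OC(C)=O)C1=C(Br)C(=C(Br)Br)OC1=O`: 1.1 ug/mL
compound 3 `CCC[C@@H](O)C1=C(Br)/C(=C/I)OC1=O`: 1.3 ug/mL

In a functional assay on Lu1 cells (Homo sapiens) for cytotoxicity (a higher number here means that more compound is needed for the effect, a lower number that less compound is needed), compound 2 gives the lowest of the three numbers, yet its gap to compound 3 and its gap to compound 1 both lie within the scatter, so the three compounds cannot be told apart on these values. Compound 4 `CCCCC1=C(Br)C(=C(Br)Br)OC1=O` has not yet been measured. It differs from compound 2 in one place: hydrogen in place of acetoxy on a saturated chain carbon bound to a double-bonded ring carbon and a saturated chain carbon. For the measured compounds named here, no step between measured compounds bears on this change, and nothing in the three values points one way or the other. The step from compound 2 to compound 4 in this assay is therefore expected to be small, at most a modest shift toward a higher number, as a 1.5-fold higher number from compound 2 to compound 4 (0.16 log units; within the scatter). Compound 4 is expected to give 1.6 ug/mL in this assay, within 0.5 ug/mL to 5 ug/mL.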

Compound 4, concentration for half-maximal effect: > 10.3 ug/mL
Compound 4: only a limit was reported (the forecaster's own chance of this, stated with the estimate: 5%); middle value at least 6.4-fold (0.80 log units) from the limit.
By their numbers in this assay, from the lowest: compounds 2, 3 and 1 (each within the scatter of the next). At a limit, above all of these: compound 4.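

In this assay, the group on this saturated chain carbon proves to matter: hydrogen in place of acetoxy gives an at least 9.3-fold higher number from compound 2 to compound 4 (0.97 log units; beyond the scatter). The reading for compound 4 is a limit, not a number: the limit of > 10.3 ug/mL in this assay, at which 1 of the 4 values shown sits. The three earlier compounds could not be told apart, and none of them showed that this change could carry such a step.

Open, on these data alone, is whether a methoxy or a benzoyloxy group on this carbon would keep the number of compound 2. Also open, as far as these compounds go, is how far the true number of compound 4 lies past its limit.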